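The source may hold more compounds than are shown below. What is called first, only, known or untested is meant among the compounds shown, and "the series" means these compounds.

Measured compounds:
compound 1, `CCn1c(C(=O)N[C@@H](C)CO)ccc1C(CC)(CC)c1ccc(OCS(=O)(=O)c2ccccc2)c(C)c1`, 10800 nM
compound 2, `CCn1c(C(=O)NC2(CO)CC2)ccc1C(CC)(CC)c1ccc(OCS(=O)(=O)c2ccccc2)c(C)c1`, 28800 nM
compound 3, `CCn1c(C(=O)N[C@@H](CO)C(C)C)ccc1C(CC)(CC)c1ccc(OCS(=O)(=O)c2ccccc2)c(C)c1`, 18800 nM

All three were tested in a functional assay on MCF7 cells (Homo sapiens) for antiproliferative activity, read by MTT assay, with a stated time of 24 h; a lower number here means a stronger inhibitor, a higher number a weaker inhibitor. Compound 3 gives 18800 nM and stands second highest of the three numbers; its nearest neighbour is compound 2 at 28800 nM, and the step of a 1.5-fold lower number from compound 2 to compound 3 (0.19 log units; within the scatter) lies within the scatter, as does a 1.7-fold higher number from compound 1 to compound 3 (0.24 log units; within the scatter). Among the compounds with values here, the only step beyond the scatter is a 2.7-fold higher number from compound 1 to compound 2 (0.43 log units; beyond the scatter), and it is modest.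

Compound 4, `CCn1c(C(=O)NCCC(=O)O)ccc1C(CC)(CC)c1ccc(OCS(=O)(=O)c2ccccc2)c(C)c1`, has not yet been measured. It differs from compound 3 in this way: 2-carboxyethyl in place of 1-(hydroxymethyl)-2-methylpropyl on an amide-type nitrogen. Within the data shown here, none of the measured steps swaps a hydroxymethyl-bearing group for a 2-carboxyethyl group, so no step bears directly on it; the steps that do exist, all at the same amide-type nitrogen, span from within the scatter up to a modest change. On that basis compound 4 is expected to give a number close to that of compound 3, with the step of a 1.3-fold higher number from compound 3 to compound 4 (0.11 log units; within the scatter) expected to stay near or just beyond the scatter. The estimate for compound 4 is 24000 nM, within a range from 9000 nM to 65000 nM.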

Compound 4, half-maximal inhibitory concentration: > 50000 nM
Compound 4: a limit, no number (the forecaster's own chance of this, stated with the estimate: 15%); middle value at least 2.0-fold (0.31 log units) from the limit.
By their numbers in this assay, from the lowest: compounds 1, 3 and 2 (each within the scatter of the next, the first and the last beyond it). At a limit, above all of these: compound 4.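

In this assay the result for compound 4 is a limit and not a number: the limit of > 50000 nM in this assay, at which 1 of the 4 values shown sits. The earlier steps shown here at the amide-type nitrogen only exchanged one hydroxymethyl-bearing group for another, whereas 2-carboxyethyl carries no hydroxymethyl and opens the widest separation yet seen at this place, with an at least 4.6-fold higher number from compound 1 to compound 4 (0.66 log units; beyond the scatter) and an at least 2.6-fold higher number from compound 3 to compound 4 (0.42 log units; beyond the scatter). One pair stays unsettled, as the floor of this step does not clear the scatter: an at least 1.7-fold higher number from compound 2 to compound 4 (0.23 log units; that floor lies within the scatter).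

Going by these compounds, what a 2-hydroxyethyl group, a methyl ester or a longer carboxylic acid chain would give on this nitrogen stays open, and with it whether the carboxylic acid or the loss of the hydroxymethyl matters here. On these data alone, how far the true figure for compound 4 lies past its limit also remains open.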